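From compound 1 to compound 4: moving an amino group

The compounds below may be only part of what the source reports. "The series", "measured", "known", "first", "only" and "open" are said of these compounds alone.

Measured so far in a functional assay on A2780 cells (Homo sapiens) for antiproliferative activity, read by CellTiter-Glo, with a stated time of 72 h (on this read-out lower numbers stand for stronger inhibition and higher numbers for weaker inhibition), are three compounds:
Compound 1 `C[C@H](NC(=O)c1ncccn1)c1ccc(NC(=O)N2CC(c3ccc(N)nc3)C2)cc1` gives 68 nM
Compound 2 `C[C@H](NC(=O)C1CCOCC1)c1ccc(NC(=O)N2CC(c3ccc(N)nc3)C2)cc1` gives 46 nM
Compound 3 `CCC(=O)N[C@@H](C)c1ccc(NC(=O)N2CC(c3ccc(N)nc3)C2)cc1` gives 58 nM

Compound 1 cannot be told apart from the other two, as its steps to both lie within the scatter. Compound 4 `C[C@H](NC(=O)c1ncccn1)c1ccc(NC(=O)N2CC(c3cncc(N)c3)C2)cc1` changes a single group (5-aminopyridin-3-yl in place of 6-aminopyridin-3-yl on a saturated ring carbon): 5-aminopyridin-3-yl in place of 6-aminopyridin-3-yl on a saturated ring carbon of a four-membered non-aromatic ring with 1 nitrogen.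

The three measured steps, a 1.5-fold lower number from compound 1 to compound 2 (0.17 log units; within the scatter) and a 1.2-fold lower number from compound 1 to compound 3 (0.07 log units; within the scatter) and a 1.3-fold higher number from compound 2 to compound 3 (0.10 log units; within the scatter) in turn, all lie within the scatter. Each of them alters the group on a carbonyl carbon, and none touches the aminopyridinyl group. They therefore give no size for this change. Among the measured compounds shown here, no measured compound carries the new group, so a step beyond the scatter remains possible in either direction. A higher number is only a cautious guess, and the expected step is a 1.8-fold higher number from compound 1 to compound 4 (0.25 log units; within the scatter) as a rough estimate. In this assay compound 4 is expected at 120 nM within an estimated range of 20 nM to 800 nM as the likely span.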

Compound 4, half-maximal inhibitory concentration: 340 nM
Beside the measured number, compound 4's estimate is 2.8-fold (0.45 log units) below it; low and high end bracket the measured number.
By their numbers in this assay, from the lowest: compounds 2, 3 and 1 (each within the scatter of the next); then compound 4.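

In this assay, among the compounds shown here, the earlier steps all altered the group on a carbonyl carbon and stayed within the scatter, so they said nothing about the aminopyridinyl group on the saturated ring carbon. For the compounds shown here, this position proves sensitive, with a 5.0-fold higher number from compound 1 to compound 4 (0.70 log units; beyond the scatter) as the first step here beyond the scatter. The entering and leaving groups have the same atoms and the same counts of hydrogen-bond donors and acceptors, so those counts do not separate them, and nothing shown here explains the loss.

From the compounds shown here alone, it remains open whether the same step would appear with the oxan-4-yl or ethyl group of compound 2 or compound 3 on the carbonyl carbon. Also open, going by these compounds, is how a plain pyridin-3-yl group or a 6-hydroxypyridin-3-yl group would compare at this ring carbon.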